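The source may report more compounds than this note shows. Statements on the series, on what has been measured and on what is new or still open speak of the compounds shown alone.

Measured in a physicochemical assay for acid dissociation, so far
Compound 1 `NS(=O)(=O)c1ccc(SCCO)c(C(=O)O)c1` gives 10.5
Compound 2 `CC(=O)OCCCc1ccc(S(N)(=O)=O)cc1` gives 10.2

Compound 2 at 10.2 lies within the scatter of compound 1 at 10.5 and cannot be told apart from it on these numbers. Compound 3 `CC(=O)OCCCCc1ccc(S(N)(=O)=O)cc1` differs from compound 2 by acetoxymethyl in place of acetoxy on a saturated chain carbon, three bonds along the chain from an aromatic carbon and the same difference, cut one bond further out, reads acetoxymethyl to 2-acetoxyethyl. Among the compounds with values here, no measured step is available to size this change. Compound 2 at 10.2 is the closest measured reference, so no shift beyond the scatter is expected in this assay in either direction. The estimated no change at the digits printed from compound 2 to compound 3 (within the scatter) stays within the scatter. For compound 3 the expected value is 10.2 with 9.9 to 10.5 as its estimated range.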

Compound 3, acid dissociation constant: 10.5
For compound 3 the middle estimate is 0.30 log units below the measured one, within the range that was stated.
By their numbers in this assay, from the lowest: compounds 2, 1 and 3 (each within the scatter of the next).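

In this assay the series now has its first one-place step, and a number 0.30 log units higher from compound 2 to compound 3 (within the scatter) is the size of that step. On a saturated chain carbon, three bonds along the chain from an aromatic carbon, acetoxymethyl in place of acetoxy therefore gives no difference that can be told from the scatter. No evidence on record bears on this result.

On these data alone, whether an amine or a carboxylic acid at this place would give a step beyond the scatter remains open. As far as these compounds go, a longer chain, such as 2-acetoxyethyl, also remains open.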